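A few compounds are considered here, and "the series" means these few. Any claim that something is new, unique, unknown or untested is made for them only; others in the source may bear on it.

Series notes. In a functional assay on M14 cells (Homo sapiens) for cytotoxicity, read by sulforhodamine B assay, with a stated time of 48 h, tested at 1 uM (a higher number here means a weaker effect of the compound at the concentration tested, a lower number a stronger effect), the measured compounds give:

compound 1 `COc1ccc(-c2cc(/C=C/C(=O)c3ccc(OC)c(OC)c3)[nH]n2)cc1` — 97%
compound 2 `COc1cc(-c2cc(/C=C/C(=O)c3ccc(Cl)c(Cl)c3)[nH]n2)cc(OC)c1OC` — 107%
compound 3 `COc1cc(C(=O)/C=C/c2cc(-c3cc(OC)c(OC)c(OC)c3)n[nH]2)cc(OC)c1OC` — 98%

Compound 2 shows the highest of the three numbers, but its gaps to compound 3 and to compound 1 both fall within the usual scatter, so the three compounds are not separated by these data; all sit near full activity, meaning little effect at the concentration tested.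

Compound 4 `COc1cc(-c2cc(/C=C/C(=O)c3ccc(F)c(F)c3)[nH]n2)cc(OC)c1OC` is not yet measured. It differs from compound 2 in one place: 3,4-difluorophenyl in place of 3,4-dichlorophenyl on a carbonyl carbon

Among the measured compounds shown here, no step between measured compounds is available to gauge this change. Given that every measured compound, including compound 2 at 107%, sits at the same level in this assay, no step beyond the scatter is expected in either direction, and the step of a number 7 percentage points lower from compound 2 to compound 4 (within the scatter) is estimated as essentially flat. Compound 4 is expected to give about 100%, within 86% to 112%.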

Compound 4, a percentage reported as activity, at one concentration (the size of the read-out at that concentration, not a potency): 86%
The estimate for compound 4 lay 14 percentage points above the measured number, within the range that was stated.
By their numbers in this assay, from the lowest: compound 4; then compounds 1, 3 and 2 (each within the scatter of the next).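

In this assay, among the compounds shown here, 3,4-difluorophenyl in place of 3,4-dichlorophenyl on a carbonyl carbon gives a number 21 percentage points lower from compound 2 to compound 4 (beyond the scatter), the only step so far that lies beyond the scatter. The read-out at this place therefore responds to the identity of the halogen pair, with the lower number marking a stronger effect at the concentration tested. Nothing at hand accounts for this step.

From the compounds shown here alone, whether a trifluoromethyl group or an amine in place of the halogens would move the number further remains open. A single concentration also leaves the potency of compound 4 undefined.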